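The compounds below may be only part of what the source reports. "The series", "measured", "known", "first", "only" and "open" are said of these compounds alone.

Of the compounds shown here, two have been read so far in an in vitro ADME assay on microsomes from liver (Rattus norvegicus) for metabolic stability; on this read-out lower numbers stand for slow clearance and higher numbers for fast clearance: compound 1 `Cc1ccc(Cn2c(=O)[nH]c3c(N)nc(-c4ncco4)cc32)cn1` and compound 2 `Cc1ccc(Cn2c(=O)[nH]c3c(N)nc(C(F)(F)F)cc32)nn1`. Compound 1 gives < 8.5 mL.min-1.g-1, which is a limit of the assay and not a number. Compound 2 gives < 11 mL.min-1.g-1, which is likewise a limit. Compound 2 therefore has no exact number, and since the only other result is also a limit, the two compounds cannot be placed in order.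

Compound 3 `Cc1cc(Cn2c(=O)[nH]c3c(N)nc(C(F)(F)F)cc32)no1` departs from compound 2 at one place, with 5-methyl-1,2-oxazol-3-yl in place of 6-methylpyridazin-3-yl on a saturated chain carbon bound to an aromatic nitrogen. Going by the values given here, no measured pair in this small set isolates such an exchange, so the expectation in this assay is for no change beyond the usual scatter, and no direction is favoured. The estimated change is a number no lower from compound 2 to compound 3 (the limit leaves the size open), which is expected to be small. For compound 3, the expected intrinsic clearance is 11 mL.min-1.g-1, with an estimated range from 6 mL.min-1.g-1 to 28 mL.min-1.g-1.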

Compound 3, intrinsic clearance in microsomes: < 9 mL.min-1.g-1
Compound 3: no number, only a limit; the forecaster's own chance of this, stated with the estimate: 55%; middle value at least 1.2-fold (0.08 log units) away from the limit.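

In this assay compound 3 gives < 9 mL.min-1.g-1, which is a limit of the assay and not a number. Compound 2 also carries only a limit, and no step can be read between compound 2 and compound 3. The compounds shown leave open the actual clearance of each compound, and whether exchanging 6-methylpyridazin-3-yl for 5-methyl-1,2-oxazol-3-yl changes it at all.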